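Adding a methyl group to a dim starting point

The source may report more compounds than this note shows. Statements on the series, on what has been measured and on what is new or still open speak of the compounds shown alone.

Of the compounds shown here, two have been measured so far. Compound 1 `O=C(O)CCc1ccc(C#Cc2ccnc(Cl)n2)cc1` is a phenylpropanoic acid joined through an alkyne to a chlorinated six-membered ring with two nitrogens. In an in vitro functional assay on 1321-N1 cells for agonist activity at Free fatty acid receptor 1 (Homo sapiens), read by fluorescence, spectrophotometry and calcium flux (on this read-out higher numbers stand for an effect only at larger amounts of compound and lower numbers for an effect already at smaller amounts), compound 1 gives 9120 nM, the lowest of the two numbers, though only barely. Compound 2 `COc1nccc(C#Cc2ccc(CCC(=O)O)cc2)n1` carries a methoxy group in place of the chloro group and in this assay compound 2 gives 9550 nM. The step of a 1.0-fold higher number from compound 1 to compound 2 (0.02 log units; within the scatter) is within the scatter, so swapping chloro for methoxy did nothing that can be told apart from noise.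

Compound 3 `Cc1cnc(Cl)nc1C#Cc1ccc(CCC(=O)O)cc1` has not yet been measured. It differs from compound 1 by methyl in place of hydrogen on an aromatic carbon. Within the data shown here, no measured step touches this position; the only step available, from chloro to methoxy, concerns a different group and was flat. Nothing here argues for a shift in either direction, so the expectation for compound 3 is a step of about a 1.1-fold lower number from compound 1 to compound 3 (0.03 log units; within the scatter), within the scatter. Compound 3 is therefore estimated at 8500 nM in this assay, expected between 3000 nM and 25000 nM.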

Compound 3, half-maximal effective concentration: 4270 nM
For compound 3 the middle estimate is 2.0-fold (0.30 log units) above the measured one, and the stated range covers the measured number.
By their numbers in this assay, from the lowest: compound 3; then compounds 1 and 2 (each within the scatter of the next).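

In this assay this ring carbon proves to be a place where a change can be read: a 2.1-fold lower number from compound 1 to compound 3 (0.33 log units; beyond the scatter) is a modest step, yet it clears the scatter, unlike the earlier swap of chloro for methoxy, where a 1.0-fold higher number from compound 1 to compound 2 (0.02 log units; within the scatter) could not be told from noise. The change itself is very small: one carbon atom with no hydrogen-bond donors or acceptors, placed on an aromatic carbon ortho to a large group and para to a chloro group, is enough for the effect to appear at a smaller amount of compound. Nothing available explains how this single methyl group moves the number.

The compounds shown leave open whether this shift belongs to methyl alone or would also appear with a longer chain such as ethyl, or with a different group such as an amine, on the same carbon. They also leave open whether the methyl group would bring a similar shift with methoxy in place of chloro, as in compound 2.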